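A few compounds are considered here, and "the series" means these few. Any claim that something is new, unique, unknown or untested is made for them only; others in the source may bear on it.

Measured compounds:
- compound 1 `O=c1[nH]c(=O)n([C@H]2C[C@H](O)[C@@H](CO)O2)cc1[N+](=O)[O-]`: 130 nM
- compound 2 `[N-]=[N+]=NCc1cn([C@H]2C[C@H](O)[C@@H](CO)O2)c(=O)[nH]c1=O`: 124000 nM
- compound 3 `CCCNc1ncnc2c1ncn2C[C@@H]1C[C@H](CO)c2ccccc21`: > 200000 nM

All three were tested in an ADME assay on L1210/0 cells (Mus musculus) for cytotoxicity, with a stated time of 48 h; on this read-out lower numbers stand for stronger inhibition and higher numbers for weaker inhibition. Compound 1 gives 130 nM. Compound 2 gives 124000 nM, the highest of the two plain numbers, with compound 1 as its nearest neighbour at a far lower number. Compound 3 is reported only as a limit of the assay, > 200000 nM, which is the limit described by the limit of > 200000 nM in this assay, at which 1 of the 3 values shown sits. For the measured compounds named here, the single measured step between neighbours is a 950-fold higher number from compound 1 to compound 2 (2.98 log units; beyond the scatter), a large rise in the number.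

The new compound is compound 4 `CCCC#Cc1cn([C@H]2C[C@H](O)[C@@H](CO)O2)c(=O)[nH]c1=O`. Compared with compound 2, the change is pent-1-yn-1-yl in place of azidomethyl on an aromatic carbon. Going by the values given here, no measured step covers this change: the one known step swaps nitro for azidomethyl, whereas here azidomethyl gives way to pent-1-yn-1-yl on the same aromatic carbon, so that step only shows that the group at this position can move the number strongly. For compound 4 a moderately lower number than that of compound 2 is expected, an estimated step of a 4.1-fold lower number from compound 2 to compound 4 (0.62 log units; beyond the scatter), with wide uncertainty. The estimate for compound 4 in this assay is 30000 nM, within a range from 5000 nM to 200000 nM.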

Compound 4, half-maximal inhibitory concentration: > 200000 nM
Compound 4 gave a limit, no number (the forecaster's own chance of this, stated with the estimate: 20%); middle value at least 6.6-fold (0.82 log units) away from the limit.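

In this assay, the reading for compound 4 is a limit of the assay and not a number: the limit of > 200000 nM in this assay, at which 2 of the 4 values shown sit.

Even so, pent-1-yn-1-yl in place of nitro on this aromatic carbon gives an at least 1500-fold higher number from compound 1 to compound 4 (3.18 log units; beyond the scatter). The earlier compounds shown here showed one group, azidomethyl, taking the number far from that of the nitro compound; now a second group, built of carbon alone, does the same, so among the three compounds that differ only at this position, the low number belongs to nitro alone. Pent-1-yn-1-yl in place of azidomethyl gives an at least 1.6-fold higher number from compound 2 to compound 4 (0.20 log units; that floor lies within the scatter), and since that floor lies within the scatter, this change cannot yet be said to separate the two groups.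

As far as these compounds go, the true gap between the azidomethyl and pent-1-yn-1-yl compounds stays unknown, as the reading for the latter has no upper end. From the compounds shown here alone, it also remains open whether another group on this carbon, such as an amine, a carboxylic acid or a bromine atom, would bring the number back toward that of the nitro compound, and so what the low number depends on.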